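The source may report more compounds than this note shows. Statements on the series, on what has been measured and on what is new or still open speak of the compounds shown alone.

In a functional assay on MCF7 cells (Homo sapiens) for cytotoxicity, read by neutral red uptake, with a stated time of 3 days (a lower number here means a stronger inhibitor, a higher number a weaker inhibitor), compound 1 `CCCCCCc1c(F)c(N)c2c(=O)cc(-c3ccc(N)c(F)c3)oc2c1F` reaches only a limit of the assay, > 10000 nM. Compound 2 `Nc1ccc(-c2cc(=O)c3c(N)c(F)c(C(=O)O)c(F)c3o2)cc1F`, with carboxy in place of hexyl on an aromatic carbon, likewise gives only a limit, > 10000 nM. Compound 3 `CN(C)CC(=O)OCc1c(F)c(N)c2c(=O)cc(-c3ccc(N)c(F)c3)oc2c1F` measures 26 nM. As far as these compounds go, the steps of an at least 380-fold lower number from compound 1 to compound 3 (2.58 log units; beyond the scatter) and an at least 380-fold lower number from compound 2 to compound 3 (2.58 log units; beyond the scatter) are large, yet their full size stays open because two of the three values sit at the limit of > 10000 nM in this assay, at which 2 of the 3 values shown sit. Within the data shown here, compound 4 `CCCCCCOCc1c(F)c(N)c2c(=O)cc(-c3ccc(N)c(F)c3)oc2c1F` differs from compound 1 by hexyloxy in place of pentyl on a saturated chain carbon bound to an aromatic carbon, and it carries none of the ((dimethylamino)methyl)carbonyl)oxy group that sets compound 3 apart. No measured step matches this change, so little movement beyond the scatter is expected, an at least 1.1-fold lower number from compound 1 to compound 4 (0.04 log units; that floor lies within the scatter). Compound 4 is estimated at 9000 nM, between 2000 nM and 40000 nM.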

Compound 4, half-maximal inhibitory concentration: 7100 nM
The estimate for compound 4 lay 1.3-fold (0.10 log units) above the measured number, within the range that was stated.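

Compounds 3 and 4 both keep the oxygen on that saturated carbon, so the oxygen alone does not account for the low number of compound 3, and the group on it matters: a 270-fold higher number from compound 3 to compound 4 (2.44 log units; beyond the scatter). Hexyloxy in place of pentyl gives an at least 1.4-fold lower number from compound 1 to compound 4 (0.14 log units; that floor lies within the scatter), and (hexyloxy)methyl in place of carboxy gives an at least 1.4-fold lower number from compound 2 to compound 4 (0.14 log units; that floor lies within the scatter). Both are only floors, with their full size open, because compounds 1 and 2 sit at a limit: the limit of > 10000 nM in this assay, at which 2 of the 4 values shown sit.

Still open, as far as these compounds go, is which part of the group on that oxygen counts. A plain hexanoyl ester, or a hexyl chain ending in a dimethylamino amine, would separate the carbonyl from the amine.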